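Dropping the methoxy from compound 2

This account rests on a few compounds, and the source may have more. Where it says the series, first, only, none or still open, it means among the compounds named here.

Three amides on a shared core have been measured: compound 1 (`O=C(/C=C/c1ccc(C(F)(F)F)cc1)Nc1nnc(-c2ccc(Br)cc2)s1`), compound 2 (`COc1ccc(-c2nnc(NC(=O)/C=C/c3ccc(C)cc3)s2)cc1`) and compound 3 (`COc1ccc(-c2nnc(NC(=O)/C=C/c3ccc(F)cc3)s2)cc1`). In a functional assay on MCF7 cells (Homo sapiens) for antiproliferative activity, read by MTT assay, with a stated time of 48 h (a lower number here means a stronger inhibitor, a higher number a weaker inhibitor), compound 2 gives the lowest number of the three (0.31 ug/mL). Compound 3 comes next (0.85 ug/mL) and compound 1 gives the highest number (1.58 ug/mL), with both gaps to compound 2 beyond the usual scatter.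

The next entry is compound 4 (`Cc1ccc(/C=C/C(=O)Nc2nnc(-c3ccccc3)s2)cc1`). Its change from compound 2 is hydrogen in place of methoxy on an aromatic carbon and reads as hydrogen in place of methoxy on an aromatic carbon, or 4-methoxyphenyl to phenyl.

Within the data shown here, no measured step touches the methoxy. Compound 1 lacks it too, but differs from compound 2 in more than one place and gives no clean reading. Among the measured compounds shown here, the only single-place step is a 2.7-fold higher number from compound 2 to compound 3 (0.44 log units; beyond the scatter) for fluoro in place of methyl, at a different place, and it serves only as a guide to size. Since compound 2 already holds the lowest value (0.31 ug/mL), a modest move towards a higher number is the likelier outcome, though the direction is weakly supported. The expected change in this assay is a 1.9-fold higher number from compound 2 to compound 4 (0.29 log units; within the scatter) (an estimate). Compound 4 is estimated at 0.6 ug/mL (expected range 0.2 ug/mL to 1.8 ug/mL).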

Compound 4, half-maximal inhibitory concentration: 1.23 ug/mL
The estimate for compound 4 lay 2.1-fold (0.31 log units) below the measured number, within the range that was stated.
By their numbers in this assay, from the lowest: compound 2; then compounds 3, 4 and 1 (each within the scatter of the next).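

In this assay, among these compounds, the change at this position comes to a 4.0-fold higher number from compound 2 to compound 4 (0.60 log units; beyond the scatter) and gives the first clean reading of it: on an aromatic carbon, para to a large group, hydrogen in place of methoxy gives a higher number, and the step lies beyond the scatter. The position is therefore not indifferent to this change, and the methoxy of compound 2 goes with the lower number, although this reading rests on a single pair with the 4-methoxyphenyl going to phenyl. Nothing available explains this step, so the two heavy atoms and the hydrogen-bond acceptor that leave can only be counted, not credited with the difference.

Among the compounds shown, only methoxy and hydrogen can be compared directly at this carbon, so it remains open whether an ethoxy, a hydroxyl or an amine there would behave like methoxy. Going by these compounds, it also remains open whether the same change would give a similar step with fluoro on the other aromatic ring, as in compound 3, in place of the methyl of compound 2.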